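Isomeric aryl swap on the sulfonamide nitrogen

The compounds below may be only part of what the source reports. "The series", "measured", "known", "first", "only" and "open" are said of these compounds alone.

Measured compounds:
compound 1 `CCCCCc1ccc(NS(=O)(=O)c2ccc(N3CCNC3=O)cc2)cc1`: 870 nM
compound 2 `CCc1ccccc1NS(=O)(=O)c1ccc(N2CCNC2=O)cc1`: 180 nM

In a functional assay on M21 cells (Homo sapiens) for antiproliferative activity, read by sulforhodamine B assay, with a stated time of 48 h (a lower number here means a stronger inhibitor, a higher number a weaker inhibitor), compound 2 holds the lowest of the two numbers; compound 1 stands higher, by a gap beyond the scatter. Compound 3 `Cc1cccc(NS(=O)(=O)c2ccc(N3CCNC3=O)cc2)c1C` is the one not yet measured. It differs from compound 2 in a single place: 2,3-dimethylphenyl in place of 2-ethylphenyl on a sulfonamide nitrogen. Among the compounds with values here, no measured pair shows this change, so the expectation rests on compound 2 alone, and the step is expected to be small, with no clear direction beyond the scatter. Compound 3 is estimated to give 250 nM, between 80 nM and 800 nM. The step this estimate means, a 1.4-fold higher number from compound 2 to compound 3 (0.14 log units; within the scatter), is expected to stay within the scatter.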

Compound 3, half-maximal inhibitory concentration: 110 nM
Compound 3: the middle estimate sits 2.3-fold (0.36 log units) above what was measured; low and high end bracket the measured number.
By their numbers in this assay, from the lowest: compounds 3 and 2 (each within the scatter of the next); then compound 1.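

In this assay, 2,3-dimethylphenyl in place of 2-ethylphenyl on a sulfonamide nitrogen gives a 1.6-fold lower number from compound 2 to compound 3 (0.21 log units; within the scatter). Two isomeric groups with the same atoms, joined differently, therefore cannot be told apart here, so at this position and for this pair the arrangement of those atoms leaves the number unchanged within the scatter. No independent measurement bears on this result. On these data alone, whether a plain phenyl, or an aryl group carrying a methoxy, a chlorine or an amine, would stay at this level in this assay remains open.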